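Chloro to fluoro on the pendant ring, two pairs

The source may hold more compounds than are shown below. What is called first, only, known or untested is meant among the compounds shown, and "the series" means these compounds.

Compound 1 `Cn1ncc2c(NC(=O)NCc3cc(C(F)(F)F)nn3-c3cccc(Cl)c3)cccc21` gives 2.3 nM in an assay on CHO-K1 cells for antagonist activity at transient receptor potential cation channel subfamily V member 1 (Homo sapiens), read by FLIPR and calcium flux, with a stated time of 6 min; on this read-out higher numbers stand for weaker inhibition and lower numbers for stronger inhibition. Compound 2 `Cn1ncc2c(NC(=O)NCc3cc(C(F)(F)F)nn3-c3cccc(F)c3)cccc21` carries the change fluoro in place of chloro on an aromatic carbon and gives 7 nM in this assay; the step is a 3.0-fold higher number from compound 1 to compound 2 (0.48 log units; beyond the scatter). Compound 3 `Cn1ncc2c(NC(=O)NCc3cc(C(C)(C)C)nn3-c3ccc(Cl)cc3)cccc21` gives 9.5 nM in this assay; the difference between the core of compound 1 and the core of compound 3 is not broken down here, and the two values simply show compound 3 with the higher number of the two. Compound 4 `Cn1ncc2c(NC(=O)NCc3cc(C(C)(C)C)nn3-c3ccc(F)cc3)cccc21` is not yet measured; relative to compound 3 it carries fluoro in place of chloro on an aromatic carbon. The place is not the same as in the earlier pair: there the fluoro sits meta to a large group, here para to a large group, so this is the same kind of change, not the same change. With one prior pair only, the expectation rests on compound 1 and compound 2, where the step was a 3.0-fold higher number from compound 1 to compound 2 (0.48 log units; beyond the scatter); a step of comparable size is expected, with added uncertainty from the different place. The expected step from compound 3 to compound 4 is a 2.6-fold higher number from compound 3 to compound 4 (0.42 log units; beyond the scatter). Compound 4 is estimated at 25 nM in this assay, between 10 nM and 60 nM.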

Compound 4, inhibition constant: 4.5 nM
Estimate against measurement, compound 4: 5.6-fold (0.74 log units) above, outside the stated range (below it).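

On the core of compound 3, fluoro in place of chloro gives a 2.1-fold lower number from compound 3 to compound 4 (0.32 log units; beyond the scatter), so in this assay the direction of the step reverses between the two pairs: the same change on two cores in this assay, a 3.0-fold higher number (0.48 log units; beyond the scatter) from compound 1 to compound 2 and a 2.1-fold lower number (0.32 log units; beyond the scatter) from compound 3 to compound 4, 6.4-fold (0.81 log units) apart, beyond the scatter of two such steps

Within these four compounds, then, the step seen on one core does not give even the direction of the step on the other, and the change cannot be carried across as a fixed increment. What this does not show is the source of the reversal: the two pairs differ both in the core and in the place of the halogen on the pendant ring, and two pairs cannot separate these.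

Open, from the compounds shown here alone, is whether the reversal follows the core or the ring place, a question that the 4-chlorophenyl and 4-fluorophenyl groups on the core of compound 1 would address. Also open, going by these compounds, is how a nitrile or a methoxy group at the same place on the pendant ring would compare with chloro and fluoro.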